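The source may hold more compounds than are shown below. What is called first, only, known or untested is meant among the compounds shown, and "the series" means these compounds.

Compound 1 `C/C=C1/[C@H](O[C@@H]2O[C@H](CO)[C@@H](O)[C@H](O)[C@H]2O)OC=C(C(=O)OC)[C@H]1CC(=O)OCc1ccco1` in a functional assay on SK-BR-3 cells (Homo sapiens) for antiproliferative activity, read by MTT assay, with a stated time of 72 h (a lower number here means a stronger inhibitor, a higher number a weaker inhibitor), gives > 15000 nM, a limit of the assay.
Compound 2 `C/C=C1/[C@H](O[C@@H]2O[C@H](CO)[C@@H](O)[C@H](O)[C@H]2O)OC=C(C(=O)OC)[C@H]1CC(=O)OCCc1ccc([N+](=O)[O-])cc1` gives > 20000 nM, also a limit.

For the measured compounds named here, the only measured step, a step that the two limits leave unreadable from compound 1 to compound 2, stays unreadable, both values being limits the limit of > 15000 nM in this assay, at which 1 of the 2 values shown sits (the limit of > 20000 nM in this assay, at which 1 of the 2 values shown sits). Compound 2 therefore stands only at a limit, with no number beneath it. Compound 3 `C/C=C1/[C@H](O[C@@H]2O[C@H](CO)[C@@H](O)[C@H](O)[C@H]2O)OC=C(C(=O)OC)[C@H]1CC(=O)OCCc1ccc(O)cc1` differs from compound 2 by hydroxy in place of nitro on an aromatic carbon. Going by the values given here, no measured step bears on this change, so no shift beyond the scatter is expected. Compound 3 is estimated at 25000 nM, between 8000 nM and 80000 nM, the expected step that the limit leaves unreadable from compound 2 to compound 3 reflecting that another limit is the likeliest outcome.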

Compound 3, half-maximal inhibitory concentration: > 20000 nM
Compound 3 ended at the assay's limit; the forecaster's own chance of this, stated with the estimate: 70%; the middle value is on the limit's open side.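

Compound 3 gives > 20000 nM, again a limit of the assay. For the compounds shown here, no step from compound 1 or compound 2 to compound 3 can be read. The compounds shown leave open whether any of the three has a measurable potency in this assay.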